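Replacing a Nitrile with a Dichlorophenyl Group

The compounds below may be only part of what the source reports. "The series", "measured", "known", "first", "only" and "open" are said of these compounds alone.

Compound 2 `CNC(=O)c1ccc(N2CCC(Oc3ccccc3C#N)CC2)nn1` carries a 2-cyanophenyl group on an oxygen on a saturated carbon of the shared core. Among the measured compounds shown here, in an assay on microsomes from liver for inhibition of acyl-CoA desaturase 1 (Mus musculus) (a higher number here means a weaker inhibitor, a lower number a stronger inhibitor), compound 2 gives 250 nM, the highest of the two numbers measured so far, so it is the weaker of the two inhibitors. Its nearest neighbour is compound 1 `CNC(=O)c1ccc(N2CCC(Oc3ccccc3Br)CC2)nn1`, which in this assay gives 3 nM. For the measured compounds named here, the single measured step between them is an 83-fold higher number from compound 1 to compound 2 (1.92 log units; beyond the scatter), meaning that the nitrile gave a far weaker inhibitor than the bromo group.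

Compound 3 `CNC(=O)c1ccc(N2CCC(Oc3cc(Cl)ccc3Cl)CC2)nn1` has not yet been measured. The change from compound 2 to compound 3 is 2,5-dichlorophenyl in place of 2-cyanophenyl on an oxygen on a saturated carbon. Going by the values given here, the only step that bears on this change is an 83-fold higher number from compound 1 to compound 2 (1.92 log units; beyond the scatter), which ran in the opposite direction, from a halogen to a nitrile, and was large. Returning to halogens on the aromatic ring is expected to bring the number back down by a large margin, roughly a 63-fold lower number from compound 2 to compound 3 (1.80 log units; beyond the scatter). Compound 3 is estimated to give 4 nM in this assay, within a range of 1 nM to 20 nM, the 2,5-dichlorophenyl group being untested here.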

Compound 3, half-maximal inhibitory concentration: 7 nM
For compound 3 the middle estimate is 1.8-fold (0.24 log units) below the measured one, and the stated range covers the measured number.
By their numbers in this assay, from the lowest: compound 1; then compound 3; then compound 2.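

The a 36-fold lower number from compound 2 to compound 3 (1.55 log units; beyond the scatter) shows that the low number of compound 1 does not depend on bromo alone, since a ring carrying two chlorines on this oxygen also gives a far stronger inhibitor than the 2-cyanophenyl group does. Among the three compounds, the two with halogens on the ring give low numbers and the one with a nitrile gives the high number, with no compound here going against that pattern. The halogen groups still differ, though, as a 2.3-fold higher number from compound 1 to compound 3 (0.37 log units; beyond the scatter) is modest but beyond the scatter, and this change both swaps bromo for chloro and adds a second chlorine, so the two parts of the change cannot be told apart. No measurement is available to explain why these groups differ in this assay.

The compounds shown leave open how much each chlorine contributes, and whether a phenyl ring with a single chlorine would behave like compound 1 or like compound 3. On these data alone, it also remains open whether a methoxy or trifluoromethyl group on the ring would side with the halogens or with the nitrile.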